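From fluoro to chloro on the shared core

The source may hold more compounds than are shown below. What is called first, only, known or untested is meant among the compounds shown, and "the series" means these compounds.

Measured so far:
compound 1 (`O=C1/C(=C/c2ccc(F)cc2)Cc2ccccc21`) gives 60000 nM
compound 2 (`O=C1/C(=C/c2cccc(Cl)c2)Cc2ccccc21`) gives 50900 nM

Both values come from a functional assay on MOLT-4 cells (Homo sapiens) for inhibition (on this read-out higher numbers stand for weaker inhibition and lower numbers for stronger inhibition), and they lie within the scatter of each other, so compound 1 stands alongside compound 2 and these numbers cannot separate the two. Compound 3 (`O=C1/C(=C/c2ccc(Cl)cc2)Cc2ccccc21`) has not yet been measured in this assay and it shares the core of compound 1. The change is a single exchange, chloro in place of fluoro on an aromatic carbon, at a place on a six-membered aromatic ring of carbon only, para to a large group. Among the measured compounds shown here, no measured pair shows this exchange, so the data give no direct size for it. For the measured compounds named here, the only guide is the narrow spread of the measured values, with compound 1 at 60000 nM and compound 2 at 50900 nM in the same range. No step beyond the scatter is expected, and any drift is expected to be slight and towards a lower number. The estimated step is a 1.3-fold lower number from compound 1 to compound 3 (0.12 log units; within the scatter) and it is expected to stay within the scatter. For compound 3 the estimate is 45000 nM with an expected range from 20000 nM to 90000 nM as the likely span.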

Compound 3, half-maximal inhibitory concentration: > 500000 nM
Compound 3 ended at the assay's limit; the forecaster's own chance of this, stated with the estimate: 10%; middle value at least 11-fold (1.04 log units) away from the limit.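

In this assay compound 3 gives > 500000 nM as a limit of the assay, not as a number. The exchange of chloro for fluoro on an aromatic carbon, at this place on a six-membered aromatic ring of carbon only, para to a large group, brings an at least 8.3-fold higher number from compound 1 to compound 3 (0.92 log units; beyond the scatter) and so shows that this place responds to a single-atom exchange, which the two earlier values, lying within the scatter of each other, could not reveal. On these data alone, the step gives only a lower bound on the change, and its true size stays unknown, since the value of compound 3 rests on the assay's limit: the limit of > 500000 nM in this assay, at which 1 of the 3 values shown sits.

Compound 2 also carries a chloro, at another place on the ring, and gives 50900 nM as a measured number, so the compounds shown leave open whether the weaker result belongs to chloro at this one place alone or to a wider demand of this place on the ring. As far as these compounds go, whether bromo, methoxy or an amine at this place would follow compound 1 or compound 3 also stays open.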